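Shortening the Chain of Compound 2

The source may hold more compounds than are shown below. What is called first, only, known or untested is meant among the compounds shown, and "the series" means these compounds.

In a functional assay on HCT-15 cells (Homo sapiens) for antiproliferative activity, read by sulforhodamine B assay (on this read-out higher numbers stand for weaker inhibition of growth and lower numbers for stronger inhibition of growth), compound 2 (`CCCCCCOc1cccc(O)c1C(=O)/C=C/c1ccc(O)cc1`) reads > 30000 nM, which is a limit and not a number. Compound 3 (`O=C(/C=C/c1ccc(O)cc1)c1c(O)cccc1OCC1CCCCC1`) reads > 30000 nM, which is also a limit. Compound 2 therefore stands at the limit of > 30000 nM in this assay, at which 2 of the 3 values shown sit. Only compound 1 (`CC(C)CCCOc1cccc(O)c1C(=O)/C=C/c1ccc(O)cc1`) gives a true number, 11600 nM.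

Compound 4 (`CCCCOc1cccc(O)c1C(=O)/C=C/c1ccc(O)cc1`) keeps the shared core of compound 2 and differs only in its chain: hydrogen in place of ethyl on a saturated chain carbon, four bonds along the chain from an oxygen on an aromatic ring. In words, this is hydrogen in place of ethyl on a saturated chain carbon, four bonds along the chain from an oxygen on an aromatic ring. The same difference can be read as pentyl to propyl.

Within the data shown here, no measured step shortens a straight chain, so the evidence is indirect. Two chain changes do bear on it: an at least 2.5-fold higher number from compound 1 to compound 2 (0.41 log units; beyond the scatter), and an at least 2.5-fold higher number from compound 1 to compound 3 (0.41 log units; beyond the scatter). Both are modest at the least, and the step that the two limits leave unreadable from compound 2 to compound 3 adds nothing. These steps show that the chain alone can shift the result in this assay, so a modest move towards a lower number, meaning stronger inhibition of growth, is expected, although compound 4 may also stay at the limit. The expected step is an at least 1.8-fold lower number from compound 2 to compound 4 (0.27 log units; that floor lies within the scatter). Compound 4 is estimated at 16000 nM, with an expected range of 6000 nM to 35000 nM.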

Compound 4, concentration for 50% growth inhibition: > 30000 nM
Compound 4 ended at the assay's limit; the forecaster's own chance of this, stated with the estimate: 35%; at least 1.8-fold (0.27 log units) between middle value and limit.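

Shortening the pentyl part of the chain to propyl does not bring the compound back from the limit. In this assay, compound 4 reads > 30000 nM, which is a limit of the assay and not a number. The steps from compound 2 to compound 4 and from compound 3 to compound 4 join one limit to another and cannot be read, while the one readable new step is an at least 2.5-fold higher number from compound 1 to compound 4 (0.41 log units; beyond the scatter), which leaves compound 1, with its isopentyl chain, as the only compound here that gives a true number, and the limit now holds most of the set: the limit of > 30000 nM in this assay, at which 3 of the 4 values shown sit.

The compounds shown leave open whether a still shorter chain, or a chain ending in an amine or a carboxylic acid, would give a true number in this assay. They also cannot tell how far compound 2, compound 3 and compound 4 lie beyond the limit, or whether these three differ from one another at all.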